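From 4-cyanophenyl to 3-(hydroxymethyl)phenyl in compound 4

The source may hold more compounds than are shown below. What is called first, only, known or untested is meant among the compounds shown, and "the series" means these compounds.

In a functional assay on PC-3 cells (Homo sapiens) for inhibition, read by sulforhodamine B assay, with a stated time of 48 h, tested at 50 uM (a higher number here means more inhibition of growth at the concentration tested, a lower number less inhibition of growth), compound 3 `COc1ccc([C@@H]2C/C(=N/OCc3cn(-c4ccc(C#N)cc4)nn3)c3cc(CC=C(C)C)c(OC)cc3O2)cc1` gives 50%. Two related compounds provide the comparison: compound 1 `CCCOc1ccc([C@@H]2CC(=O)c3cc(CC=C(C)C)c(OC)cc3O2)cc1` gives 54%, and compound 2 `COc1ccc([C@@H]2C/C(=N/OCc3cn(-c4ccc(C(=O)c5ccccc5)cc4)nn3)c3cc(CC=C(C)C)c(OC)cc3O2)cc1` gives 40%. The number for compound 3 lies within the usual scatter of both, so repeat measurements alone could account for those gaps, and compound 3 cannot be ranked against either.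

Compound 4 `COc1ccc([C@@H]2C/C(=N/OCc3cn(-c4cccc(CO)c4)nn3)c3cc(CC=C(C)C)c(OC)cc3O2)cc1` keeps the rest of compound 3 and alters one group: 3-(hydroxymethyl)phenyl in place of 4-cyanophenyl on an aromatic nitrogen. In words, 3-(hydroxymethyl)phenyl stands in place of 4-cyanophenyl on an aromatic nitrogen of a five-membered aromatic ring with 3 nitrogen.

Among the measured compounds shown here, only one measured step bears on this change: a number 10 percentage points higher from compound 2 to compound 3 (within the scatter). That step puts cyano in place of benzoyl on the aromatic ring that is replaced here, and it stays within the scatter. For the measured compounds named here, it is a modest guide, since no measured compound carries the hydroxymethyl group and the data cannot show what that group does.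

No clear direction can be drawn from this, so the expected result is an estimated a number 2 percentage points lower from compound 3 to compound 4 (within the scatter), with no step beyond the scatter. For compound 4 the estimated value in this assay is 48%, with an expected range of 33% to 63%.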

Compound 4, percent growth inhibition at one concentration: 34%
For compound 4 the middle estimate is 14 percentage points above the measured one; measured number inside the range.
By their numbers in this assay, from the lowest: compounds 4, 2, 3 and 1 (each within the scatter of the next, the first and the last beyond it).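

In this assay, putting 3-(hydroxymethyl)phenyl in place of 4-cyanophenyl on the aromatic nitrogen gives a number 16 percentage points lower from compound 3 to compound 4 (beyond the scatter). The group at this position can thus change growth inhibition by more than the usual scatter. The earlier step at this position, a number 10 percentage points higher from compound 2 to compound 3 (within the scatter), could not show this, and the new step is the only one shown here that clears the scatter. Both groups have 8 heavy atoms and one six-membered aromatic ring, so the counted difference lies elsewhere: the hydroxymethyl group brings a hydrogen-bond donor that 4-cyanophenyl lacks, but no measurement shown here explains why growth inhibition falls.

The step changes both the group on the phenyl ring and its location in the name, so 3-cyanophenyl and 4-(hydroxymethyl)phenyl would be needed to tell these two changes apart. From the compounds shown here alone, it also remains open how this position would respond to a 3-(aminomethyl)phenyl group or a phenyl ring carrying a carboxylic acid.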